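Working notes: from compound 3 to compound 4

This account rests on a few compounds, and the source may have more. Where it says the series, first, only, none or still open, it means among the compounds named here.

Measured in a functional assay on HCT-116 cells (Homo sapiens) for inhibition; a lower number here means that less compound is needed, a higher number that more compound is needed for the effect:
- compound 1 `COc1cc(N2CCN(Cc3ccccn3)CC2)ccc1Nc1nc(NC2CCCCC2)c2nc[nH]c2n1` gives 89 nM
- compound 2 `COc1cc(N2CCN(C(=O)N3CCC(O)C3)CC2)ccc1Nc1nc(NC2CCCCC2)c2nc[nH]c2n1` gives 100 nM
- compound 3 `COc1cc(N2CCC(C(=O)N3CCC(N(C)C)C3)CC2)ccc1Nc1nc(NC2CCCCC2)c2nc[nH]c2n1` gives 77 nM

Compound 3 stands level with compound 1 and compound 2, since all three values lie within the scatter of one another and no order can be read among them. Compound 4 `COc1cc(N2CCC(CC(=O)N3CCC(N(C)C)C3)CC2)ccc1Nc1nc(NC2CCCCC2)c2nc[nH]c2n1` differs from compound 3 in one place: ((3-(dimethylamino)pyrrolidin-1-yl)carbonyl)methyl in place of (3-(dimethylamino)pyrrolidin-1-yl)carbonyl on a saturated ring carbon with ((3-(dimethylamino)pyrrolidin-1-yl)carbonyl)methyl in place of (3-(dimethylamino)pyrrolidin-1-yl)carbonyl on a saturated ring carbon. Within the data shown here, no measured step covers this change. Among the measured compounds shown here, the only step available, a 1.1-fold higher number from compound 1 to compound 2 (0.05 log units; within the scatter) for a different exchange on an amine nitrogen in a ring, stayed within the scatter, which offers weak, indirect support at best. No shift beyond the scatter is therefore expected, in either direction. The expected 1.0-fold higher number from compound 3 to compound 4 (0.02 log units; within the scatter) remains within the scatter on this reading. In this assay the estimated value for compound 4 is 80 nM with an expected range of 35 nM to 180 nM as a working figure.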

Compound 4, half-maximal effective concentration: 97 nM
Compound 4: middle estimate off by 1.2-fold (0.08 log units), on the low side; measured number inside the range.
By their numbers in this assay, from the lowest: compounds 3, 1, 4 and 2 (each within the scatter of the next).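

Among these compounds, the step of a 1.3-fold higher number from compound 3 to compound 4 (0.10 log units; within the scatter) in this assay is the first at a saturated ring carbon of a six-membered non-aromatic ring with 1 nitrogen; the earlier step lay on an amine nitrogen in a ring. It shows that ((3-(dimethylamino)pyrrolidin-1-yl)carbonyl)methyl can take the place of (3-(dimethylamino)pyrrolidin-1-yl)carbonyl without a shift beyond the scatter. Nothing at hand accounts for this result. The compounds shown leave open whether a longer chain between this ring carbon and the carbonyl would also stay within the scatter. They also leave open whether a carboxylic acid or a primary amine at the same place would do so.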